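The source may hold more compounds than are shown below. What is called first, only, known or untested is meant among the compounds shown, and "the series" means these compounds.

Compound 1 `FC(F)(F)c1ccc(CN2CCN(Cc3cc(-c4ccc(OCc5ccccc5)cc4)on3)CC2)cc1` gives 11700 nM in a functional assay on Mahlavu cells (Homo sapiens) for antiproliferative activity, read by sulforhodamine B assay, with a stated time of 72 h; on this read-out higher numbers stand for weaker inhibition and lower numbers for stronger inhibition. Compound 2 `Cc1ccccc1COc1ccc(-c2cc(CN3CCN(Cc4ccc(C(F)(F)F)cc4)CC3)no2)cc1` gives 6800 nM in this assay. Compound 3 `N#Cc1cccc(COc2ccc(-c3cc(CN4CCN(Cc5ccc(C(F)(F)F)cc5)CC4)no3)cc2)c1` gives 10600 nM in this assay.

Compound 2 differs from compound 1 by methyl in place of hydrogen on an aromatic carbon, and the step was a 1.7-fold lower number from compound 1 to compound 2 (0.24 log units; within the scatter). The core of compound 3 differs from that of compound 1 by cyano in place of hydrogen on an aromatic carbon, while compound 2 and compound 3 differ by a 1.6-fold higher number from compound 2 to compound 3 (0.19 log units; within the scatter). Compound 4 `Cc1cc(-c2cc(CN3CCN(Cc4ccc(C(F)(F)F)cc4)CC3)no2)ccc1OCc1cccc(C#N)c1` is not yet measured; it differs from compound 3 by methyl in place of hydrogen on an aromatic carbon. This is the same kind of change as that from compound 1 to compound 2, but the place differs: in compound 4 it is ortho to a (3-cyanobenzyl)oxy group and meta to a large group, not ortho to a large group. Compound 4 is expected to show a step of a 1.4-fold lower number from compound 3 to compound 4 (0.15 log units; within the scatter), resting on compound 2 having shown a 1.7-fold lower number from compound 1 to compound 2 (0.24 log units; within the scatter). The estimate for compound 4 is 7500 nM, between 3500 nM and 16000 nM.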

Compound 4, half-maximal inhibitory concentration: 450 nM
For compound 4 the middle estimate is 17-fold (1.22 log units) above the measured one; measured number outside the range, below it.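

In this assay, methyl in place of hydrogen on an aromatic carbon gave a 24-fold lower number from compound 3 to compound 4 (1.37 log units; beyond the scatter), and the two uses of this change do not agree in size: the same change on two cores in this assay, a 1.7-fold lower number (0.24 log units; within the scatter) from compound 1 to compound 2 and a 24-fold lower number (1.37 log units; beyond the scatter) from compound 3 to compound 4, 14-fold (1.14 log units) apart, beyond the scatter of two such steps. The effect of the change therefore did not carry over from one core to the other in these two pairs. This does not show whether the gap comes from the cores or from where the methyl sits, since in compound 4 it is ortho to a (3-cyanobenzyl)oxy group and in compound 2 it is not.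

The compounds shown leave open whether a methyl at that same place would give a similar step on the core of compound 1. They also leave open whether a chlorine or a methoxy group in place of that methyl would match compound 4.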